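A heteroaryl exchange on the shared core

A few compounds are considered here, and "the series" means these few. Any claim that something is new, unique, unknown or untested is made for them only; others in the source may bear on it.

Compound 1 `COc1ccc(/C=N/NC(=S)NC(C)(C)[C@H]2CC=C(C)CC2)cc1` and compound 2 `CC1=CC[C@H](C(C)(C)NC(=S)N/N=C/c2cccc(Cl)c2)CC1` share a core and differ only in the aromatic group on a carbon with a double bond to nitrogen. In a functional assay on UACC-62 cells (Homo sapiens) for inhibition, read by sulforhodamine B assay, with a stated time of 48 h (on this read-out lower numbers stand for stronger inhibition of growth and higher numbers for weaker inhibition of growth), compound 1 gives 13300 nM, and compound 2 gives 9000 nM. Compound 1 stands at the higher of the two numbers shown, but the gap to compound 2 is within the scatter: the single measured step, a 1.5-fold lower number from compound 1 to compound 2 (0.17 log units; within the scatter), shows that one aromatic group in place of another at this carbon left the number within the scatter.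

Compound 3 `CC1=CC[C@H](C(C)(C)NC(=S)N/N=C/c2cccs2)CC1` has not yet been measured. It differs from compound 1 by thiophen-2-yl in place of 4-methoxyphenyl on a carbon with a double bond to nitrogen. The step from compound 1 to compound 2 is the only one that bears on this change, and it was within the scatter, so for compound 3 in this assay no step beyond the scatter is expected. Compound 3 is therefore estimated at 11000 nM, with a range from 4000 nM to 30000 nM. This corresponds to an expected step of a 1.2-fold lower number from compound 1 to compound 3 (0.08 log units; within the scatter).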

Compound 3, concentration for 50% growth inhibition: 2600 nM
For compound 3 the middle estimate is 4.2-fold (0.63 log units) above the measured one, outside the stated range (below it).
By their numbers in this assay, from the lowest: compound 3; then compounds 2 and 1 (each within the scatter of the next).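

Unlike the earlier exchange at this carbon, changing the aromatic group here moves the number in this assay beyond the scatter, both with thiophen-2-yl in place of 4-methoxyphenyl (a 5.1-fold lower number from compound 1 to compound 3 (0.71 log units; beyond the scatter)) and with thiophen-2-yl in place of 3-chlorophenyl (a 3.5-fold lower number from compound 2 to compound 3 (0.54 log units; beyond the scatter)). The position on a carbon with a double bond to nitrogen is therefore not indifferent to the group it carries, and among these three compounds the five-membered aromatic ring with 1 hetero atom stands apart from the two six-membered aromatic rings of carbon only. Nothing measured here accounts for this difference.

The compounds shown leave open whether the sulfur atom or the smaller ring goes with the lower number. A furan-2-yl or thiophen-3-yl group at this carbon would bear on that question, as would a pyridin-2-yl group.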